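A few compounds are considered here, and "the series" means these few. Any claim that something is new, unique, unknown or untested is made for them only; others in the source may bear on it.

Measured compounds:

Compound 1, `CCOC(=O)C12C(=O)OCC=C1COC2c1ccccc1F`. In a functional assay on QGY cells (Homo sapiens) for cytotoxicity, read by MTT assay (on this read-out lower numbers stand for stronger inhibition and higher numbers for weaker inhibition), compound 1 gives > 1000000 nM, a limit of the assay rather than a number.

Compound 2, `CCOC(=O)C12C(=O)OCC=C1COC2c1ccc(F)cc1`. In this assay compound 2 gives > 1000000 nM, likewise a limit.

Compound 3, `CCOC(=O)C12C(=O)OCC=C1COC2c1ccc(Cl)c(Cl)c1`. In this assay compound 3 gives > 1000000 nM, again a limit.

Compound 2 therefore stands where every value shown stands, at the limit of > 1000000 nM in this assay, at which 3 of the 3 values shown sit. Only a limit is known for it, and the two other values are limits too. Within the data shown here, the single step between measured compounds that differ in one place, a step that the two limits leave unreadable from compound 1 to compound 2, has no readable size, since both ends are limits. Compound 4, `CCOC(=O)C12C(=O)OCC=C1COC2c1ccc(OC)cc1`, is to be measured in this assay; relative to compound 2 the change is methoxy in place of fluoro on an aromatic carbon. Among the measured compounds shown here, no measured step covers an exchange of fluoro for methoxy, and the one step that is recorded, a step that the two limits leave unreadable from compound 1 to compound 2, gives no size to lean on. Since all three values shown sit at the limit, compound 4 is expected to sit there as well, with an expected step of a number no higher from compound 2 to compound 4 (the limit leaves the size open), none readable beyond the scatter. The estimate for compound 4 is 1000000 nM, between 200000 nM and 5000000 nM, most probably reported again only as a limit.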

Compound 4, half-maximal inhibitory concentration: > 1000000 nM
Compound 4 gave a limit, no number; the forecaster's own chance of this, stated with the estimate: 85%; the middle value lies on the limit itself.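

The exchange of fluoro for methoxy joining compound 2 and compound 4 links two limits, so no size can be read for it. The compounds shown leave open whether any change on the aromatic ring yields a numerical value in this assay and how such changes would rank: the limit of > 1000000 nM in this assay, at which 4 of the 4 values shown sit.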